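The source may hold more compounds than are shown below. What is called first, only, known or untested is meant among the compounds shown, and "the series" means these compounds.

Working notes on the series built around the shared core of compound 1 `CN1CCN(C[C@H]2CN(c3ccc(-n4cc(-c5ccccn5)cn4)c(F)c3)C(=O)O2)CC1`. In an ADME assay on L02 cells (Homo sapiens) for cytotoxicity, read by MTT assay, with a stated time of 48 h (a higher number here means a weaker inhibitor, a lower number a stronger inhibitor), compound 1 gives 70 ug/mL. Compound 2 `O=C1O[C@@H](CN2CCC(O)CC2)CN1c1ccc(-n2cc(-c3ccccn3)cn2)c(F)c1` carries a 4-hydroxypiperidin-1-yl in place of the 4-methylpiperazin-1-yl on a saturated chain carbon bound to a saturated ring carbon. In this assay compound 2 reaches only > 400 ug/mL, which is a limit of the assay and not a number. Compound 3 `O=C1CCC(=O)N1C[C@H]1CN(c2ccc(-n3cc(-c4ccccn4)cn3)c(F)c2)C(=O)O1` carries a 2,5-dioxopyrrolidin-1-yl on a saturated chain carbon bound to a saturated ring carbon. In this assay compound 3 likewise gives > 400 ug/mL, again a limit rather than a number. The steps of an at least 5.7-fold higher number from compound 1 to compound 2 (0.75 log units; beyond the scatter) and an at least 5.7-fold higher number from compound 1 to compound 3 (0.75 log units; beyond the scatter) both run towards weaker inhibition, while the step that the two limits leave unreadable from compound 2 to compound 3. Compound 2 therefore stands at the limit of > 400 ug/mL in this assay, at which 2 of the 3 values shown sit.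

Compound 4 `NC(=O)[C@H]1CN(c2ccc(-n3cc(-c4ccccn4)cn3)c(F)c2)C(=O)O1` is not yet measured; it differs from compound 2 by carbamoyl in place of (4-hydroxypiperidin-1-yl)methyl on a saturated ring carbon. Among the measured compounds shown here, no measured step removes the chain altogether and places a group directly on the ring carbon, so the only guidance is that both departures from the 4-methylpiperazin-1-yl of compound 1 ended at the limit. The step of a number no higher from compound 2 to compound 4 (the limit leaves the size open) is therefore expected to stay within the scatter, with a limit again the most likely outcome. Compound 4 is estimated at 400 ug/mL, within 200 ug/mL to 800 ug/mL.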

Compound 4, half-maximal inhibitory concentration: 119 ug/mL
Estimate against measurement, compound 4: 3.4-fold (0.53 log units) above; the whole stated range lies above it.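

In this assay, the saturated ring carbon next to the ring oxygen turns out not to be tied to the limit: with carbamoyl in place of the chain-linked groups, the series moves back towards stronger inhibition, with an at least 3.3-fold lower number from compound 2 to compound 4 (0.52 log units; beyond the scatter) and an at least 3.3-fold lower number from compound 3 to compound 4 (0.52 log units; beyond the scatter). Set against the basic reference point of the series, a 1.7-fold higher number from compound 1 to compound 4 (0.23 log units; within the scatter), so carbamoyl, with no ring, and (4-methylpiperazin-1-yl)methyl cannot be told apart in this assay. Loss of the 4-methylpiperazin-1-yl therefore does not by itself carry a compound to the limit, since compound 4 lacks it and still gives a measured number, while compound 2 and compound 3 stay at a limit of the assay and not a number: the limit of > 400 ug/mL in this assay, at which 2 of the 4 values shown sit.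

The change to compound 4 replaces the whole substituent at once, so the compounds shown do not separate the effect of the carbamoyl from that of losing the methylene link to the ring carbon. A carboxylic acid on the same ring carbon, or a 2-carbamoylethyl chain in that place, would leave open whether the reading follows the amide or the chain length.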